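A few compounds are considered here, and "the series" means these few. Any claim that something is new, unique, unknown or untested is made for them only; others in the source may bear on it.

Of the compounds shown here, three have been read in an ADME assay on T29 cells (Homo sapiens) for cytotoxicity, read by sulforhodamine B assay, with a stated time of 3 days (a lower number here means a stronger inhibitor, a higher number a weaker inhibitor), and all three stand at limits. Compound 1 `O=Cc1cn(Cc2cccc(C(F)(F)F)c2)c2ccccc12` gives > 31600 nM as a limit of the assay, not a number. Compound 2 `OCc1cn(Cc2cccc(F)c2)c2ccccc12` gives > 31600 nM as a limit too. Compound 3 `OCc1cn(Cc2cccc(I)c2)c2ccccc12` gives > 31600 nM as a limit as well, so it offers no number to step from, and the two other values shown are also limits. Compound 4 `OCc1cn(Cc2cccc(C(F)(F)F)c2)c2ccccc12` is not yet measured and carries trifluoromethyl in place of iodo on an aromatic carbon, meta to a large group: trifluoromethyl in place of iodo on an aromatic carbon. Among the compounds with values here, the one measured step bearing on this change is a step that the two limits leave unreadable from compound 2 to compound 3 with iodo in place of fluoro on an aromatic carbon, and it gives neither size nor direction. Within the data shown here, the series so far reads as the limit of > 31600 nM in this assay, at which 3 of the 3 values shown sit, and no more. No step beyond the scatter is therefore expected in this assay, and compound 4 is expected to report the same limit. For compound 4 the estimate is 35000 nM with an expected range from 15000 nM to 60000 nM as the bounds. The expected step is a step that the limit leaves unreadable from compound 3 to compound 4 and no more than that.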

Compound 4, half-maximal inhibitory concentration: > 31600 nM
Compound 4 ended at the assay's limit; the forecaster's own chance of this, stated with the estimate: 85%; the middle value is on the limit's open side.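

No step to compound 4 from compound 1, compound 2 or compound 3 can be read in this assay, as each value is a limit and not a number: the limit of > 31600 nM in this assay, at which 4 of the 4 values shown sit.

The compounds shown leave open whether any of these group changes alters cytotoxicity in this series.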